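The compounds below may be only part of what the source reports. "The series", "measured", "known", "first", "only" and "open" are said of these compounds alone.

Measured in a functional assay on COLO 205 cells (Homo sapiens) for inhibition, read by sulforhodamine B assay, with a stated time of 48 h, tested at 50 uM (a higher number here means more inhibition of growth at the concentration tested, a lower number less inhibition of growth), so far:
Compound 1 `COc1cc(/C=C/C(=O)/C=C/c2cccc3ccccc23)ccc1OCc1cn(CCCOc2cc(=O)oc3ccccc23)nn1` gives 64%
Compound 2 `COc1ccccc1/C=C/C(=O)/C=C/c1ccc(OCc2cn(CCCOc3cc(=O)oc4ccccc34)nn2)c(OC)c1` gives 57%
Compound 3 `COc1cc(/C=C/C(=O)/C=C/c2ccccc2)ccc1OCc1cn(CCCOc2cc(=O)oc3ccccc23)nn1` gives 43%

Compound 3 stands lowest of these three, beyond the scatter from both of the others. Compound 4 `COc1cc(/C=C/C(=O)/C=C/c2cc(OC)c(OC)c(OC)c2)ccc1OCc1cn(CCCOc2cc(=O)oc3ccccc23)nn1` differs from it in one place, with 3,4,5-trimethoxyphenyl in place of phenyl on a double-bonded chain carbon bound to a double-bonded chain carbon.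

Within the data shown here, two measured steps bear directly on this place, since both end at the phenyl group. One is a number 21 percentage points lower from compound 1 to compound 3 (beyond the scatter) and the other is a number 14 percentage points lower from compound 2 to compound 3 (beyond the scatter). Among these three compounds, none goes against the phenyl group giving the lowest number. The remaining step, a number 7 percentage points lower from compound 1 to compound 2 (within the scatter), does not separate the two larger groups. Among the measured compounds shown here, no measured compound carries the 3,4,5-trimethoxyphenyl group, so this reading rests on other groups at the same place. Leaving phenyl for a different group is therefore expected to raise the number modestly, by about the size of those two steps. The expected step is a number 15 percentage points higher from compound 3 to compound 4 (beyond the scatter) in this assay. The estimate for compound 4 is 58%, with an expected range from 42% to 74%.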

Compound 4, percent growth inhibition at one concentration: 74%
Compound 4: the middle estimate sits 16 percentage points below what was measured; the range from low to high includes it.
By their numbers in this assay, from the lowest: compound 3; then compounds 2, 1 and 4 (each within the scatter of the next, the first and the last beyond it).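

In this assay, among these compounds, the 3,4,5-trimethoxyphenyl group brings the largest change yet seen at this place, a number 31 percentage points higher from compound 3 to compound 4 (beyond the scatter), which shows that the room for improvement over phenyl is wider than the earlier compounds indicated. Among the compounds shown here, it also separates two methoxy-bearing groups for the first time, with a number 17 percentage points higher from compound 2 to compound 4 (beyond the scatter), so the group on a double-bonded chain carbon bound to a double-bonded chain carbon matters beyond the mere presence of a methoxy group, while naphthalen-1-yl, which carries no methoxy group, goes against any rule that methoxy groups are needed, as the comparison with it reads a number 10 percentage points higher from compound 1 to compound 4 (within the scatter) and does not separate the two. Nothing available explains why these groups differ in this way.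

The compounds shown leave open how a phenyl ring carrying an amine or a carboxylic acid would compare at this place, and whether a longer chain in place of the one joining the two parts of the core would change these steps. They also leave open whether the order seen at one concentration in this assay would hold at other concentrations.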